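HDAC6 inhibition: swapping a four-membered ring for a pyridine

A few compounds are considered here, and "the series" means these few. Any claim that something is new, unique, unknown or untested is made for them only; others in the source may bear on it.

Measured compounds:
- compound 1 `COc1cc2nc(-c3ccc(C)o3)cc(NCC3CCN(Cc4ccc(C(=O)NO)s4)CC3)c2cc1OC`: 66 nM
- compound 2 `COc1cc2nc(-c3ccc(C)o3)cc(NCC3CCN(C4CC(C(=O)NO)C4)CC3)c2cc1OC`: 3180 nM

In an assay on isolated protein for inhibition of protein deacetylase HDAC6 (Homo sapiens), read by fluorescence, with a stated time of 30 min (a higher number here means a weaker inhibitor, a lower number a stronger inhibitor), compound 1 gives 66 nM and compound 2 gives 3180 nM. Going by the values given here, compound 2 stands at the highest number of the two, with compound 1 as its only neighbour: a 48-fold higher number from compound 1 to compound 2 (1.68 log units; beyond the scatter), a change in which an aromatic five-membered ring carrying the hydroxamic acid was replaced by a four-membered non-aromatic ring on the amine nitrogen in a ring.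

Compound 3 `COc1cc2nc(-c3ccc(C)o3)cc(NCC3CCN(c4ccc(C(=O)NO)cn4)CC3)c2cc1OC` reverses that direction: a group of 10 heavy atoms (6 carbon, 2 nitrogen, 2 oxygen; one six-membered aromatic ring with 1 hetero atom) in place of a group of 8 heavy atoms (5 carbon, 1 nitrogen, 2 oxygen; one four-membered non-aromatic ring of carbon only), on an amine nitrogen in a ring. The hydroxamic acid again sits on an aromatic ring attached to the same ring nitrogen, as in compound 1. Among the compounds with values here, only the step from compound 1 to compound 2 bears on this change, and it was large, so compound 3 is expected to move strongly back toward compound 1, with a 32-fold lower number from compound 2 to compound 3 (1.50 log units; beyond the scatter). The estimate for compound 3 in this assay is 100 nM, within 30 nM to 400 nM.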

Compound 3, half-maximal inhibitory concentration: 465 nM
Compound 3: the middle estimate sits 4.7-fold (0.67 log units) below what was measured; the measured number lies above the stated range.
By their numbers in this assay, from the lowest: compound 1; then compound 3; then compound 2.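

In this assay the 5-(hydroxycarbamoyl)pyridin-2-yl group on the amine nitrogen in a ring recovers only part of the gap left by the four-membered ring (a 6.8-fold lower number from compound 2 to compound 3 (0.83 log units; beyond the scatter)). An aromatic ring carrying the hydroxamic acid at this position therefore does not by itself restore the number seen with compound 1, as the two aromatic groups, equal in heavy-atom count, still differ (a 7.0-fold higher number from compound 1 to compound 3 (0.85 log units; beyond the scatter)). No measurement here accounts for that difference.

Ring size, the sulfur or nitrogen in the ring, and the way the ring is joined to the amine nitrogen all change together between compound 1 and compound 3, so their separate contributions remain open. A phenyl ring carrying the hydroxamic acid, or the same pyridine joined through a methylene group, could begin to separate them.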